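Swapping the Ring on the Carbonyl Carbon: Compound 4

The source may hold more compounds than are shown below. What is called first, only, known or untested is meant among the compounds shown, and "the series" means these compounds.

Three measured compounds share one core and differ only in the aromatic ring attached to the carbonyl carbon. Compound 1 `CCOc1ccc(C(=O)/C=C/c2c(/C=C/c3ccc(OC)cc3)cc(OC)cc2OC)cc1` carries a 4-ethoxyphenyl there; in a functional assay on HepG2 cells (Homo sapiens) for antiproliferative activity, read by MTT assay, with a stated time of 48 h (a higher number here means a weaker inhibitor, a lower number a stronger inhibitor), compound 1 gives 8 ug/mL. Compound 2 `COc1ccc(/C=C/c2cc(OC)cc(OC)c2/C=C/C(=O)c2cccc(Cl)c2)cc1` carries a 3-chlorophenyl, and in this assay compound 2 gives 9.5 ug/mL, the highest of the three numbers, although its gaps to the other two lie within the scatter. Compound 3 `COc1ccc(/C=C/c2cc(OC)cc(OC)c2/C=C/C(=O)c2ccccc2C)cc1` carries a 2-methylphenyl; in this assay compound 3 gives 5.3 ug/mL. The steps between them are a 1.2-fold higher number from compound 1 to compound 2 (0.07 log units; within the scatter), a 1.5-fold lower number from compound 1 to compound 3 (0.18 log units; within the scatter) and a 1.8-fold lower number from compound 2 to compound 3 (0.25 log units; within the scatter): every exchange of the ring on the carbonyl carbon seen so far has stayed within the scatter.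

Compound 4 `CCN(CC)c1ccc(C(=O)/C=C/c2c(/C=C/c3ccc(OC)cc3)cc(OC)cc2OC)cc1` has not yet been measured. Its difference from compound 2 is 4-(diethylamino)phenyl in place of 3-chlorophenyl on a carbonyl carbon. All three measured steps bear on this change: each is a swap of the same ring at the same place, and none moved the number beyond the scatter. The same outcome is therefore expected here, a step not beyond the scatter in either direction. For compound 4 the expected step is a 1.3-fold lower number from compound 2 to compound 4 (0.10 log units; within the scatter). The estimate for compound 4 in this assay is 7.5 ug/mL, with a range from 3.5 ug/mL to 16 ug/mL.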

Compound 4, half-maximal inhibitory concentration: 6.3 ug/mL
Beside the measured number, compound 4's estimate is 1.2-fold (0.08 log units) above it; the measured number falls inside the stated range.
By their numbers in this assay, from the lowest: compounds 3, 4, 1 and 2 (each within the scatter of the next).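

The 4-(diethylamino)phenyl brings a nitrogen and a hydrogen-bond acceptor where 3-chlorophenyl has a chlorine and no acceptor, yet in this assay this exchange gives a 1.5-fold lower number from compound 2 to compound 4 (0.18 log units; within the scatter) and so adds a more differently built ring without a step beyond the scatter. Measured against the 2-methylphenyl, the same ring gives a 1.2-fold higher number from compound 3 to compound 4 (0.08 log units; within the scatter); the exchange of diethylamino for ethoxy on an aromatic carbon, which leaves the rest of the ring in place, gives a 1.3-fold lower number from compound 1 to compound 4 (0.10 log units; within the scatter) and shows that this smaller change also stays within the scatter, so that all four rings on the carbonyl carbon now sit within the scatter of one another, with no compound shown going against that. Nothing measured alongside these numbers offers an explanation for how close they lie.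

The compounds shown all keep an aromatic ring on the carbonyl carbon, so it remains open whether a saturated ring such as cyclohexyl, or a plain methyl, would give a step beyond the scatter. On these data alone, it is equally open whether a carboxylic acid on the ring would do so.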